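The source may hold more compounds than are shown below. What is called first, only, known or untested is meant among the compounds shown, and "the series" means these compounds.

The measured compounds: compound 1, `CC1CCCc2c1nc(N)c(C#N)c2-c1cccn1C`, with 47900 nM in a functional assay on HOP-92 cells (Homo sapiens) for inhibition, read by sulforhodamine B assay, with a stated time of 48 h; a higher number here means a weaker inhibitor of growth, a lower number a stronger inhibitor of growth; compound 2, `COc1ccc(-c2cc(-c3cccn3C)c(C#N)c(=O)[nH]2)cc1OC`, with 50 nM in this assay. Compound 3, `Cn1cccc1-c1cc(-c2cccs2)nc(N)c1C#N`, gives only a limit in this assay, > 100000 nM. Compound 3 therefore stands at the limit of this assay, where one of the three values shown sits (the limit of > 100000 nM in this assay, at which 1 of the 3 values shown sits), and compound 2 gives the lowest number of the three. Compound 4, `Cn1cccc1-c1cc(-c2ccccc2)nc(N)c1C#N`, differs from compound 3 by phenyl in place of thiophen-2-yl on an aromatic carbon. Among the compounds with values here, no step between two measured compounds carries this change, so its size has not been seen here. The step from compound 3 to compound 4 is expected to stay within the scatter, a number no higher from compound 3 to compound 4 (the limit leaves the size open). Compound 4 is expected near 100000 nM, within 20000 nM to 300000 nM, with a limit again likely.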

Compound 4, concentration for 50% growth inhibition: 10 nM
Estimate against measurement, compound 4: 10000-fold (4.00 log units) above, outside the stated range (below it).
By their numbers in this assay, from the lowest: compound 4; then compound 2; then compound 1. At a limit, above all of these: compound 3.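

In this assay, replacing thiophen-2-yl with phenyl on the aromatic carbon next to the ring nitrogen gives an at least 10000-fold lower number from compound 3 to compound 4 (4.00 log units; beyond the scatter). This shows that, with the rest of the molecule unchanged, the ring at this position alone can shift the growth-inhibition read-out far beyond the scatter. Compound 3 gives only a limit, so the step is a bound and not an exact size: the limit of > 100000 nM in this assay, at which 1 of the 4 values shown sits.

The compounds shown leave open whether a pyridyl ring or a saturated cyclohexyl group would keep the low number of compound 4. They also leave open whether a chloro or methoxy group on the phenyl ring would change it.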